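Hydrazide series: methoxy on the aryl ring

This account rests on a few compounds, and the source may have more. Where it says the series, first, only, none or still open, it means among the compounds named here.

Two compounds of this series have a number in an assay on mitochondria for inhibition of Amine oxidase [flavin-containing] A (Bos taurus), read by fluorescence, with a stated time of 60 min; on this read-out higher numbers stand for weaker inhibition and lower numbers for stronger inhibition. Compound 1 `COC(=O)CN1C(=O)c2ccccc2NC1c1ccc(OC)cc1` gives in this assay 48 nM. Compound 2 `NNC(=O)CN1C(=O)c2ccccc2NC1c1ccccc1` gives in this assay 38 nM. Compound 2 holds the lower of the two numbers, but the pair sits within the scatter of the method, so the two values show no difference that can be read as order.

The next step goes from compound 2 to compound 3 `COc1ccc(C2Nc3ccccc3C(=O)N2CC(=O)NN)cc1`, which differs by methoxy in place of hydrogen on an aromatic carbon, para to a large group. Among the measured compounds shown here, no matched pair among the measured compounds isolates this change, so its weight in this assay is not known from the data at hand.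

Given that compound 1 and compound 2 lie within the scatter of each other, no step beyond the scatter is expected in this assay for compound 3; the estimated step of a 1.1-fold lower number from compound 2 to compound 3 (0.04 log units; within the scatter) is expected to be small. Compound 3 is estimated at 35 nM, with a range from 15 nM to 90 nM.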

Compound 3, half-maximal inhibitory concentration: 82 nM
For compound 3 the middle estimate is 2.3-fold (0.37 log units) below the measured one; measured number inside the range.
By their numbers in this assay, from the lowest: compounds 2, 1 and 3 (each within the scatter of the next, the first and the last beyond it).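

In this assay the change from phenyl to 4-methoxyphenyl now has a matched pair, and methoxy in place of hydrogen on this aromatic carbon, para to a large group, gives a 2.2-fold higher number from compound 2 to compound 3 (0.33 log units; beyond the scatter) as a modest weakening of inhibition. With the 4-methoxyphenyl group held constant, aminoamino in place of methoxy on a carbonyl carbon gives a 1.7-fold higher number from compound 1 to compound 3 (0.23 log units; within the scatter) and so shows no readable difference at that end of the molecule. The data offer no measurement that accounts for the step on the aromatic ring.

Still open, going by these compounds, is whether this step belongs to methoxy specifically or would appear with other groups on the same aromatic carbon, such as a hydroxy, a chlorine or an ethoxy. The compounds shown also leave open whether the methoxy step carries over to the methyl ester side of the series, and how a carboxylic acid or a primary amide on the same carbonyl carbon would compare.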